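The source may report more compounds than this note shows. Statements on the series, on what has been measured and on what is new or still open speak of the compounds shown alone.

In a functional assay on WM 266-4 cells (Homo sapiens) for antiproliferative activity, read by MTT assay, with a stated time of 24 h (a lower number here means a stronger inhibitor of growth, a higher number a weaker inhibitor of growth), the three measured compounds give these numbers:

Compound 1 `COc1ccc(C2=NN(C(=O)c3cncc(Br)c3)C(c3ccc(Cl)cc3)C2)cc1` gives 1290 nM.
Compound 2 `COc1ccc(C2=NN(C(=O)c3cncc(Br)c3)C(c3ccc(OCc4ccccc4)cc3)C2)cc1` gives 6240 nM.
Compound 3 `O=C(c1cncc(Br)c1)N1N=C(c2ccc(Cl)cc2)CC1c1ccc(OCc2ccccc2)cc1` gives 8130 nM.

All three share one core and differ only in the groups on its two outer rings. Compound 2 and compound 3 differ in the change (chloro in place of methoxy on an aromatic carbon), with a step of a 1.3-fold higher number from compound 2 to compound 3 (0.11 log units; within the scatter). Compound 2 and compound 1 differ in the change (chloro in place of benzyloxy on an aromatic carbon), with a step of a 4.8-fold lower number from compound 2 to compound 1 (0.68 log units; beyond the scatter).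

Compound 4 `O=C(c1cncc(Br)c1)N1N=C(c2ccc(Cl)cc2)CC1c1ccc(Cl)cc1` has not yet been measured in this assay. It differs from compound 3 by chloro in place of benzyloxy on an aromatic carbon, the same change as between compound 2 and compound 1. Because that change gave a 4.8-fold lower number from compound 2 to compound 1 (0.68 log units; beyond the scatter), a step of about a 4.8-fold lower number from compound 3 to compound 4 (0.68 log units; beyond the scatter) is expected from compound 3 to compound 4. Compound 4 is therefore estimated at 1700 nM, between 700 nM and 4200 nM.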

Compound 4, concentration for 50% growth inhibition: 6090 nM
Compound 4: the middle estimate sits 3.6-fold (0.55 log units) below what was measured, and the stated range ends below it.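

In this assay, chloro in place of benzyloxy gives a 1.3-fold lower number from compound 3 to compound 4 (0.13 log units; within the scatter), so this change does not keep its size when carried from the core of compound 2 to the core of compound 3: the same change on two cores in this assay, a 4.8-fold lower number (0.68 log units; beyond the scatter) from compound 2 to compound 1 and a 1.3-fold lower number (0.13 log units; within the scatter) from compound 3 to compound 4, 3.6-fold (0.56 log units) apart, beyond the scatter of two such steps. Chloro in place of methoxy gives a 4.7-fold higher number from compound 1 to compound 4 (0.67 log units; beyond the scatter), and its size also depends on the core that carries it: the same change on two cores in this assay, a 1.3-fold higher number (0.11 log units; within the scatter) from compound 2 to compound 3 and a 4.7-fold higher number (0.67 log units; beyond the scatter) from compound 1 to compound 4, 3.6-fold (0.56 log units) apart, beyond the scatter of two such steps. The two changes are therefore not independent in these four compounds, so a step seen on one core cannot simply be added to another, but the numbers do not show why this happens.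

The compounds shown leave open whether the same dependence would appear with other groups, such as fluoro, hydroxy or an amine. As far as these compounds go, it also remains open whether it extends beyond these four compounds.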